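A few compounds are considered here, and "the series" means these few. Any claim that something is new, unique, unknown or untested is made for them only; others in the source may bear on it.

Compound 1 `COc1cc(C(=O)/C=C/c2c[nH]c3ccccc23)cc([N+](=O)[O-])c1OC`: 1290 nM
Compound 2 `COc1cc(C(=O)/C=C/c2cn(C)c3ccccc23)cc(N)c1OC`: 631 nM

Both compounds were tested in a functional assay on MCF7 cells (Homo sapiens) for antiproliferative activity, read by MTT assay, with a stated time of 48 h; on this read-out lower numbers stand for stronger inhibition and higher numbers for weaker inhibition. Compound 2 has the lower of the two numbers, and compound 1 lies above it by a margin beyond the scatter. Compound 3 `COc1cc(C(=O)/C=C/c2cn(C)c3ccccc23)cc([N+](=O)[O-])c1OC` differs from compound 2 by nitro in place of amino on an aromatic carbon. Among the compounds with values here, no measured pair isolates this change. Compound 1, which also carries nitro, gives 1290 nM, so a small move towards a higher number in this assay is expected, probably not beyond the scatter. The expected size is a 1.5-fold higher number from compound 2 to compound 3 (0.18 log units; within the scatter). For compound 3 the estimated value is 950 nM, with an expected range of 300 nM to 2800 nM.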

Compound 3, half-maximal inhibitory concentration: 1770 nM
Compound 3: middle estimate off by 1.9-fold (0.27 log units), on the low side; measured number inside the range.
By their numbers in this assay, from the lowest: compound 2; then compounds 1 and 3 (each within the scatter of the next).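

In this assay the amino-to-nitro change at this position, ortho to a methoxy group, can now be read on its own: it gives a 2.8-fold higher number from compound 2 to compound 3 (0.45 log units; beyond the scatter) and so counts against nitro here. With nitro on the ring, methyl in place of hydrogen on the aromatic nitrogen gives a 1.4-fold higher number from compound 1 to compound 3 (0.14 log units; within the scatter) and does not separate the two compounds. Nothing at hand bears on the reason for either step. Still open, as far as these compounds go, is where a hydroxyl or an acetamide at this position would fall, and whether that methyl matters when amino sits on the ring.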